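Removing the heptyl chain from a benzimidazole antihistamine

This account rests on a few compounds, and the source may have more. Where it says the series, first, only, none or still open, it means among the compounds named here.

Compound 1: `CCCCCCCn1c(N2CCN(C)CC2)nc2ccccc21` — 150 nM
Compound 2: `CCOCCn1c(N2CCNCC2)nc2ccccc21` — 11 nM

For the measured compounds named here, in a functional assay on ileum for inhibition of histamine H1 receptor (Cavia porcellus) (a lower number here means a stronger inhibitor, a higher number a weaker inhibitor), compound 1 gives 150 nM, the higher of the two numbers measured so far. Compound 2 gives 11 nM, a gap well beyond the scatter; the two structures differ in several places, so no single change can be read from that pair.

Compound 3, `CN1CCN(c2nc3ccccc3[nH]2)CC1`, has not yet been measured. It differs from compound 1 in one place: hydrogen in place of heptyl on an aromatic nitrogen. Going by the values given here, no measured pair shows this change, so its effect is a matter of expectation only. He expects the loss of the chain to weaken the inhibitor, with a 3.0-fold higher number from compound 1 to compound 3 (0.48 log units; beyond the scatter) as the expected step, since compound 2 at 11 nM still carries a substituent on that nitrogen. For compound 3 the estimate is 450 nM, within the range 100 nM to 2000 nM.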

Compound 3, half-maximal inhibitory concentration: > 3000 nM
Compound 3: no number, only a limit (the forecaster's own chance of this, stated with the estimate: 15%); middle value at least 6.6-fold (0.82 log units) away from the limit.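

Compound 3 gives > 3000 nM in this assay, which is a limit of the assay and not a number. With hydrogen in place of heptyl on the aromatic nitrogen, the change brings an at least 20-fold higher number from compound 1 to compound 3 (1.30 log units; beyond the scatter), the first one-place change read at this position, and it shows that in this pair the heptyl chain counts for much of the inhibition. The full size of the step stays unknown, since it is bounded only from one side: the limit of > 3000 nM in this assay, at which 1 of the 3 values shown sits.

The compounds shown leave open how much of the heptyl chain is needed, since a shorter chain such as propyl, or a benzyl group, on this nitrogen with the 4-methylpiperazin-1-yl group kept would place the step more closely. They also leave open whether a chain longer than heptyl would give a lower number than compound 1 at 150 nM.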